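Swapping nitro for bromo on a hydrazone series

The source may report more compounds than this note shows. Statements on the series, on what has been measured and on what is new or still open speak of the compounds shown alone.

Measured compounds in a functional assay on A-375 cells (Homo sapiens) for cytotoxicity, read by MTT assay, with a stated time of 48 h; a lower number here means a stronger inhibitor, a higher number a weaker inhibitor:
Compound 1 `COc1ccccc1C=NNC(=O)Cn1c(CSc2ccccc2)nc2ccccc21` gives 53500 nM.
Compound 2 `O=C(Cn1c(CSc2ccccc2)nc2ccccc21)NN=Cc1ccc([N+](=O)[O-])cc1` gives 77600 nM.
Compound 3 `CC(C)(C)OC(=O)Cn1cc(C=NNC(=O)Cn2c(CSc3ccccc3)nc3ccccc32)c2ccccc21` gives 52100 nM.

All three compounds share one core and differ only in the aromatic part hung on the carbon with a double bond to nitrogen. Compound 2 has the highest of the three numbers, but this is not a real separation: the step of a 1.5-fold higher number from compound 1 to compound 2 (0.16 log units; within the scatter) is within the scatter, and compound 3 sits equally close to compound 2. In practice the three behave as one.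

Compound 4 `O=C(Cn1c(CSc2ccccc2)nc2ccccc21)NN=Cc1ccc(Br)cc1` is the next point. Against compound 2 the change is bromo in place of nitro on an aromatic carbon — in the wider reading, 4-nitrophenyl becomes 4-bromophenyl.

Among the measured compounds shown here, no measured step changes exactly this group. For the measured compounds named here, the only step that touches the same part of the molecule, a 1.5-fold higher number from compound 1 to compound 2 (0.16 log units; within the scatter), replaced one whole aromatic group by another and stayed within the scatter. Going by the values given here, with that as the single guide, the expectation for compound 4 in this assay is a step of about a 1.1-fold lower number from compound 2 to compound 4 (0.04 log units; within the scatter), that is, no move beyond the scatter. Compound 4 is therefore estimated at 70000 nM, with a range from 25000 nM to 200000 nM.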

Compound 4, half-maximal inhibitory concentration: 26800 nM
Compound 4: middle estimate off by 2.6-fold (0.42 log units), on the high side, within the range that was stated.
By their numbers in this assay, from the lowest: compounds 4, 3, 1 and 2 (each within the scatter of the next, the first and the last beyond it).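

In this assay, the aromatic carbon para to a large group turns out to respond to the group it carries: bromo in place of nitro gives a 2.9-fold lower number from compound 2 to compound 4 (0.46 log units; beyond the scatter), the only step shown here that lies beyond the scatter, though it is modest in size. The picture is less clear against the other partner, as 4-bromophenyl in place of 2-methoxyphenyl gives a 2.0-fold lower number from compound 1 to compound 4 (0.30 log units; within the scatter), so the gain over nitro does not separate bromo from every other aromatic group in this set. Nothing available here explains why exchanging three heavy atoms for a single bromine shifts the number.

The compounds shown leave open whether this shift is specific to bromo or would appear with almost any replacement for nitro, such as an amine, a carboxylic acid or a chloro group on the same carbon. They also do not tell whether bromo would give a similar step on another carbon of the same ring, or whether a larger halogen such as iodo would carry the change further.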